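This account rests on a few compounds, and the source may have more. Where it says the series, first, only, none or still open, it means among the compounds named here.

Compound 1 `Cn1cc(SCC(=O)Nc2ccccc2Cl)c2ccccc21` in an ADME assay on HEK-293T cells (Homo sapiens) for cytotoxicity, read by CCK-8 assay, with a stated time of 48 h; on this read-out lower numbers stand for higher toxicity in this test and higher numbers for lower toxicity in this test: > 100000 nM
Compound 2 `Cn1cc(SCC(=O)Nc2cccc(Cl)c2Cl)c2ccccc21` in this assay : > 100000 nM

In this assay compound 1 gives > 100000 nM, and this is a limit of the assay, not a measured number. Compound 2 gives in this assay > 100000 nM, which is again only a limit. So compound 1 stands at the edge of what this test can read, with no number of its own, and the same holds for the only other compound shown: the limit of > 100000 nM in this assay, at which 2 of the 2 values shown sit.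

Compound 3 `Cn1cc(SCC(=O)Nc2ccc(Cl)cc2Cl)c2ccccc21` has not yet been measured. It differs from compound 1 in one place: chloro in place of hydrogen on an aromatic carbon. Among the measured compounds shown here, one measured step bears on this change, the step from compound 1 to compound 2 in this assay, a step that the two limits leave unreadable from compound 1 to compound 2, which is also a chloro in place of hydrogen on the same ring; because both of its ends are limits, its size cannot be read. No direction for compound 3 can therefore be drawn from the data. Compound 3 is expected to sit at the same limit, so the step from compound 1 to compound 3 is estimated as a step that the limit leaves unreadable from compound 1 to compound 3, none beyond the scatter. For compound 3 the estimate in this assay is 150000 nM, with a range from 60000 nM to 500000 nM.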

Compound 3, half-maximal cytotoxic concentration: > 100000 nM
Compound 3: a limit, no number; the forecaster's own chance of this, stated with the estimate: 80%; the middle value does not contradict the limit.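

In this assay compound 3 gives > 100000 nM, which is a limit and not a number, so the step from compound 1 to compound 3 cannot be read. The three compounds shown share one result: the limit of > 100000 nM in this assay, at which 3 of the 3 values shown sit. Going by these compounds, whether the added chloro changes toxicity in this test at all, and at what concentration compound 1, compound 2 or compound 3 would harm these cells, stays open.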